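Swapping a benzyloxy group for methylsulfanyl

This account rests on a few compounds, and the source may have more. Where it says the series, first, only, none or still open, it means among the compounds named here.

compound 1 `CC(C)Oc1ccccc1-c1ncc(C(=O)O)c(=O)[nH]1`: 0.8 mg/kg
compound 2 `O=C(O)c1cnc(-c2ccccc2OCc2ccccc2)[nH]c1=O`: 5 mg/kg

For the measured compounds named here, in a functional assay on the whole organism (strain Sprague-Dawley) for inhibition, with Rattus norvegicus as the target, with a stated time of 10 min (on this read-out lower numbers stand for an effect already at smaller amounts and higher numbers for an effect only at larger amounts of compound), compound 2 has the higher of the two numbers, so it needs the larger dose, and compound 1 is its only neighbour. The next structure is compound 3 `CSc1ccccc1-c1ncc(C(=O)O)c(=O)[nH]1` and the change is this: methylsulfanyl in place of benzyloxy on an aromatic carbon with the shared core untouched. Going by the values given here, only one measured step bears on it: a 6.3-fold higher number from compound 1 to compound 2 (0.80 log units; beyond the scatter) when benzyl took the place of isopropyl on an oxygen. Methylsulfanyl has no ring, so compound 3 may fall back towards compound 1 (0.8 mg/kg) although sulfur in this spot is untested and one pair is thin evidence. The expected change is a 3.3-fold lower number from compound 2 to compound 3 (0.52 log units; beyond the scatter) towards a lower number. For compound 3 the estimate is 1.5 mg/kg with an expected range from 0.4 mg/kg to 6 mg/kg in this test.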

Compound 3, dose for 50% inhibition: > 20 mg/kg
Compound 3 was reported as a limit; the forecaster's own chance of this, stated with the estimate: 5%; at least 13-fold (1.12 log units) between middle value and limit.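

In this assay compound 3 is reported only as a limit, not as a measured number: the limit of > 20 mg/kg in this assay, at which 1 of the 3 values shown sits. Even so, the limit is enough to place it, with an at least 4.0-fold higher number from compound 2 to compound 3 (0.60 log units; beyond the scatter), and with an at least 25-fold higher number from compound 1 to compound 3 (1.39 log units; beyond the scatter). On this aromatic carbon, a smaller group therefore does not by itself bring the number down: compound 1 and compound 3 both lack the ring of benzyloxy, yet methylsulfanyl gives the highest number of the three, well away from isopropoxy.

The compounds shown leave open whether the sulfur or the short chain goes with this large rise. A methoxy group on the same carbon would set oxygen against sulfur directly, and an ethylsulfanyl group would test a longer chain on sulfur.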